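The source may hold more compounds than are shown below. What is called first, only, known or untested is meant among the compounds shown, and "the series" means these compounds.

Measured compounds: compound 1 `CCCN(CC[C@H]1CC[C@H](NC(=O)/C=C/c2cccc(F)c2)CC1)[C@H]1CCc2nc(N)sc2C1` gives 9.9 nM in an assay on brain for displacement of a labelled ligand from D(3) dopamine receptor (Rattus norvegicus); a higher number here means a weaker inhibitor, a lower number a stronger inhibitor; compound 2 `CCCN(CC[C@H]1CC[C@H](NC(=O)/C=C/c2ccccc2Cl)CC1)[C@H]1CCc2nc(N)sc2C1` gives 1.2 nM; compound 3 `CCCN(CC[C@H]1CC[C@H](NC(=O)/C=C/c2ccccc2OC)CC1)[C@H]1CCc2nc(N)sc2C1` gives 8.1 nM.

Among these three numbers compound 3 stands second highest, with compound 1 nearest at a gap within the scatter and compound 2 furthest, as shown by a 6.8-fold higher number from compound 2 to compound 3 (0.83 log units; beyond the scatter). Compound 4 `CCCN(CC[C@H]1CC[C@H](NC(=O)c2ccc3ccccc3n2)CC1)[C@H]1CCc2nc(N)sc2C1` differs from compound 3 in one place: quinolin-2-yl in place of 2-(2-methoxyphenyl)ethenyl on a carbonyl carbon. Within the data shown here, none of the measured steps swaps the whole ethenyl-aryl group for a bicyclic aromatic group, so none bears on it directly; an 8.3-fold lower number from compound 1 to compound 2 (0.92 log units; beyond the scatter) and a 1.2-fold lower number from compound 1 to compound 3 (0.09 log units; within the scatter) only show that changes in this region move this assay by modest amounts or not at all. The expected step is therefore a 1.4-fold lower number from compound 3 to compound 4 (0.13 log units; within the scatter), with direction uncertain. Compound 4 is estimated at 6 nM, range 1.5 nM to 30 nM.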

Compound 4, inhibition constant: 1.6 nM
Compound 4: the middle estimate sits 3.8-fold (0.57 log units) above what was measured; the range from low to high includes it.
By their numbers in this assay, from the lowest: compounds 2 and 4 (each within the scatter of the next); then compounds 3 and 1 (each within the scatter of the next).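

In this assay, the ethenyl-aryl chain on the carbonyl carbon can give way to quinolin-2-yl, which has no double bond outside aromatic rings, without loss: the change gives a 5.1-fold lower number from compound 3 to compound 4 (0.70 log units; beyond the scatter) and a 6.2-fold lower number from compound 1 to compound 4 (0.79 log units; beyond the scatter), while a 1.3-fold higher number from compound 2 to compound 4 (0.12 log units; within the scatter) leaves compound 4 level with compound 2. The earlier compounds shown here, all ethenyl-aryl amides, could not show that a bicyclic aromatic group is tolerated here. Nothing in the data shown gives a reason for these steps.

From the compounds shown here alone, it remains open whether naphthalen-2-yl, with carbon in place of the ring nitrogen, would match compound 4, and whether single-ring pyridin-2-yl on the same carbonyl carbon would do so.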